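Swapping the side chain of compound 2 for a hydroxyethyl group

The source may hold more compounds than are shown below. What is called first, only, known or untested is meant among the compounds shown, and "the series" means these compounds.

The three measured compounds share a core and an amide-linked glycine unit, differing at the chain carbon of the amino acid and at the ester end. In a functional assay on the whole organism (Tail, strain ICR) with Mus musculus as the target, in the tail flick test, with a stated time of 60 min, at a dose of 25 umol/kg by the oral route (on this read-out lower numbers stand for a weaker effect and higher numbers for a stronger effect at the one dose given), compound 2 (`N=C(N)NCCC[C@H](NC(=O)CN(c1nc(Cl)nc2[nH]cnc12)C1CC1)C(=O)O`) gives 51%, the highest of the three numbers; compound 1 (`O=C(CN(c1nc(Cl)nc2[nH]cnc12)C1CC1)NCC(=O)OCc1ccccc1`) gives 41.9%, which lies within the scatter of compound 2, while compound 3 (`N=C(N)NCCC[C@H](NC(=O)CN(c1nc(Cl)nc2[nH]cnc12)C1CC1)C(=O)OCc1ccccc1`) gives 30.6%, beyond it. Compound 4 (`C[C@@H](O)[C@H](NC(=O)CN(c1nc(Cl)nc2[nH]cnc12)C1CC1)C(=O)O`) differs from compound 2 by a group of 3 heavy atoms (2 carbon, 1 oxygen; no ring) in place of a group of 7 heavy atoms (4 carbon, 3 nitrogen; no ring), on a saturated chain carbon bound to an amide-type nitrogen and a carbonyl carbon. Among the compounds with values here, two measured steps touch this position or the acid end: a number 11.3 percentage points lower from compound 1 to compound 3 (beyond the scatter), and a number 20.4 percentage points lower from compound 2 to compound 3 (beyond the scatter). Within the data shown here, the first shows that adding the seven-atom group onto the glycine benzyl ester lowered the read-out modestly, so its removal in compound 4 is not expected to cost activity, although the entering hydroxyethyl group has no measured precedent here. A step of a number 1 percentage points lower from compound 2 to compound 4 (within the scatter) is therefore expected, not beyond the scatter. Compound 4 is estimated at 50%, within a range of 30% to 70%.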

Compound 4, a percentage reported as activity, at one dose (the size of the read-out at that dose, not a potency): 30.1%
Beside the measured number, compound 4's estimate is 19.9 percentage points above it; the measured number falls inside the stated range.
By their numbers in this assay, from the lowest: compounds 4 and 3 (each within the scatter of the next); then compounds 1 and 2 (each within the scatter of the next).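

In this assay, the seven-atom group on the saturated chain carbon proves not to be dispensable on the free acid: replacing it with 1-hydroxyethyl gives a number 20.9 percentage points lower from compound 2 to compound 4 (beyond the scatter), a step beyond the scatter. The earlier step of a number 11.3 percentage points lower from compound 1 to compound 3 (beyond the scatter) had linked the same seven-atom group to a lower number on the benzyl ester, so its contribution at this position is not the same in the two series, although the group it replaces differs between the steps. Nothing measured here accounts for the drop.

The compounds shown leave open whether the lower number follows from losing the seven-atom group or from introducing 1-hydroxyethyl. They also do not show whether a simple amine on a longer chain at this carbon, on the free acid, would hold the read-out of compound 2.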